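Bromo added to the ester-bearing ring of compound 2

The source may report more compounds than this note shows. Statements on the series, on what has been measured and on what is new or still open speak of the compounds shown alone.

Compound 2 `COC(=O)c1cccc(CSc2nc3ccccc3n2CC(=O)O)c1` gives 450 nM in an assay on HEK293 cells for displacement of a labelled ligand from prostaglandin D2 receptor 2 (Homo sapiens) (a higher number here means a weaker inhibitor, a lower number a stronger inhibitor), the second highest of the three measured numbers. Compound 1 `O=C(O)Cn1c(SCc2cccc(Br)c2)nc2ccccc21` gives 370 nM, and the step of a 1.2-fold higher number from compound 1 to compound 2 (0.09 log units; within the scatter) stays within the scatter. Compound 3 `COC(=O)c1cc(CSc2nc3ccccc3n2CC(=O)O)ccc1Br` gives 980 nM, and the step of a 2.2-fold higher number from compound 2 to compound 3 (0.34 log units; beyond the scatter) is a modest but real weakening. Compound 4 `COC(=O)c1ccc(Br)c(CSc2nc3ccccc3n2CC(=O)O)c1` differs from compound 2 by bromo in place of hydrogen on an aromatic carbon, on a carbon para to the methoxycarbonyl group. Among the compounds with values here, the only measured step of the same kind is the bromo addition from compound 2 to compound 3, which weakened binding modestly; the swap from compound 1 to compound 2 does not bear on it. A similar modest rise is therefore expected, a 1.8-fold higher number from compound 2 to compound 4 (0.25 log units; within the scatter). Compound 4 is estimated at 800 nM, within 350 nM to 1800 nM.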

Compound 4, half-maximal inhibitory concentration: 45 nM
Estimate against measurement, compound 4: 18-fold (1.25 log units) above, and the stated range ends above it.
By their numbers in this assay, from the lowest: compound 4; then compounds 1 and 2 (each within the scatter of the next); then compound 3.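

Bromo in place of hydrogen, ortho to a large group and para to a methoxycarbonyl group, gives a 10-fold lower number from compound 2 to compound 4 (1.00 log units; beyond the scatter), whereas the same exchange on another carbon of that ring gives a 2.2-fold higher number from compound 2 to compound 3 (0.34 log units; beyond the scatter). The outcome of this change therefore depends on which carbon carries the bromo, and even its direction reverses within the one ring. Nothing available accounts for this difference.

The compounds shown leave open whether chloro or methoxy on this carbon would match bromo, and whether the gain holds with a carboxylic acid in place of the methoxycarbonyl group.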